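Adding a Methyl to the Pendant Phenyl Ring

The source may hold more compounds than are shown below. What is called first, only, known or untested is meant among the compounds shown, and "the series" means these compounds.

Of the compounds shown here, three have been measured. Compound 1, `COc1cc2c(Oc3ccc(NC(=O)c4cc(-c5ccccc5F)ccn4)cc3F)ccnc2cc1OCCCN1CCCCC1`, gives 130 nM in a functional assay on NCI-H460 cells (Homo sapiens) for cytotoxicity, read by MTT assay, with a stated time of 72 h; on this read-out higher numbers stand for weaker inhibition and lower numbers for stronger inhibition. Compound 2, `COc1cc2c(Oc3ccc(NC(=O)c4cc(-c5ccc(C(F)(F)F)cc5)ccn4)cc3F)ccnc2cc1OCCCN1CCCCC1`, gives 360 nM. Compound 3, `COc1cc2c(Oc3ccc(NC(=O)c4cc(-c5ccccc5)ccn4)cc3F)ccnc2cc1OCCCN1CCCCC1`, gives 120 nM.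

Compound 3 has the lowest number of the three, but its gap to compound 1 lies within the scatter; only compound 2 stands clearly apart from it. Compound 4, `COc1cc2c(Oc3ccc(NC(=O)c4cc(-c5ccc(C)cc5)ccn4)cc3F)ccnc2cc1OCCCN1CCCCC1`, differs from compound 3 by methyl in place of hydrogen on an aromatic carbon. Among the measured compounds shown here, two steps bear on this change. a 1.1-fold lower number from compound 1 to compound 3 (0.03 log units; within the scatter) shows that a small fluoro on that ring hardly moved the number, whereas a 3.0-fold lower number from compound 2 to compound 3 (0.48 log units; beyond the scatter) shows that a trifluoromethyl raised it modestly. A methyl is a single carbon, so in this assay a small step toward a higher number, or none beyond the scatter, is expected. Compound 4 is estimated at 170 nM, with an expected range from 80 nM to 400 nM. This estimate means an expected 1.4-fold higher number from compound 3 to compound 4 (0.15 log units; within the scatter).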

Compound 4, half-maximal inhibitory concentration: 160 nM
Compound 4: middle estimate off by 1.1-fold (0.03 log units), on the high side; the measured number falls inside the stated range.
By their numbers in this assay, from the lowest: compounds 3, 1 and 4 (each within the scatter of the next); then compound 2.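

In this assay, methyl in place of hydrogen gives a 1.3-fold higher number from compound 3 to compound 4 (0.12 log units; within the scatter), and the comparison with the 2-fluorophenyl compound gives a 1.2-fold higher number from compound 1 to compound 4 (0.09 log units; within the scatter), so a methyl at this place, para to a large group, joins hydrogen and fluoro in one group within the scatter. Only trifluoromethyl stands apart at this position, with a 2.3-fold lower number from compound 2 to compound 4 (0.35 log units; beyond the scatter) as the swap to methyl. Nothing measured here explains that gap.

As far as these compounds go, whether an amine, a carboxylic acid or a longer chain at this same place would stay within the scatter of compound 3 remains open.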